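A Short Chain Grows Longer

The source may hold more compounds than are shown below. What is called first, only, known or untested is meant among the compounds shown, and "the series" means these compounds.

Among the measured compounds shown here, only two compounds have been tested so far, and only one of them gave a true number. For the measured compounds named here, in a functional assay on HBL-100 cells (Homo sapiens) for antiproliferative activity, read by sulforhodamine B assay, with a stated time of 48 h (on this read-out lower numbers stand for stronger inhibition of growth and higher numbers for weaker inhibition of growth), compound 2 (`CCC(C#CC(=O)OC)O/C=C/C(=O)OC`) gives 320 nM as the only number available. In this assay compound 1 (`CCCCCCC(C#CC(=O)O)O/C=C/C(=O)OC`) reads > 100000 nM and this reading is a limit of the assay, not a number.

The next molecule, compound 3 (`CCCCCCC(C#CC(=O)OC)O/C=C/C(=O)OC`), has not yet been measured. The change from compound 2 is butyl in place of hydrogen on a saturated chain carbon, three bonds along the chain from an oxygen on an unsaturated carbon and a triple-bonded carbon and nothing else. Put another way, butyl replaces hydrogen on a saturated chain carbon, so that ethyl becomes hexyl. Going by the values given here, no pair of measured compounds shows what such a change does, so there is no direct guide to its size. Any expectation must start from compound 2 at 320 nM and allow for movement in either direction. A modest loss of growth inhibition seems the likelier outcome, with a 2.5-fold higher number from compound 2 to compound 3 (0.40 log units; beyond the scatter) as the expected step. For compound 3 the estimate is 800 nM and the expected range runs from 150 nM to 5000 nM in this wide allowance.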

Compound 3, concentration for 50% growth inhibition: 2500 nM
The estimate for compound 3 lay 3.1-fold (0.49 log units) below the measured number, and the stated range covers the measured number.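

In this assay, the saturated chain carbon proves sensitive to what it carries: butyl in place of hydrogen, which turns ethyl into hexyl, gives a 7.8-fold higher number from compound 2 to compound 3 (0.89 log units; beyond the scatter). Growth inhibition weakens but is not lost, so this position accepts the longer chain at a modest cost. The compounds also now show the effect of a second change. Methyl in place of hydrogen on an oxygen next to a carbonyl group gives an at least 40-fold lower number from compound 1 to compound 3 (1.60 log units; beyond the scatter), a large step that makes this methyl matter far more than the chain change when hexyl is present. Compound 1 reads as a limit of the assay and not a number, so this large step has no exact size: the limit of > 100000 nM in this assay, at which 1 of the 3 values shown sits.

With only ethyl and hexyl shown, the compounds leave open whether the number rises steadily with chain length, and what a propyl chain or a longer chain such as octyl would give. They also leave open how an amine on this chain would read, and whether removing the same methyl with ethyl in place of hexyl would cost as much.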